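A few compounds are considered here, and "the series" means these few. Any claim that something is new, unique, unknown or untested is made for them only; others in the source may bear on it.

Compound 1 `COc1cccc(Nc2nccc(-c3ccc(C)o3)n2)c1` is measured alongside compound 2 `CN(C)c1ccc(Nc2nccc(-c3cccs3)n2)cc1` and compound 3 `Cc1cccc(Nc2nccc(-c3ccc(C)o3)n2)c1`. In a functional assay for inhibition, with Homo sapiens as the target (on this read-out lower numbers stand for stronger inhibition and higher numbers for weaker inhibition), compound 1 gives 1500 nM, compound 3 gives 2000 nM, and compound 2 gives 900 nM; compound 1 stands second highest of the three, and both other numbers lie within the scatter of it. Among the compounds with values here, the only step between single-change neighbours, a 1.3-fold higher number from compound 1 to compound 3 (0.12 log units; within the scatter), is within the scatter as well. Compound 4 `COc1cccc(Nc2nccc(-c3ccc(C)s3)n2)c1` differs from compound 1 by 5-methylthiophen-2-yl in place of 5-methylfuran-2-yl on an aromatic carbon. Within the data shown here, no measured step touches this change, and compound 2 differs from compound 1 in more than one place, so its value shows only that the two numbers lie close together. The step of a 1.3-fold lower number from compound 1 to compound 4 (0.10 log units; within the scatter) is therefore expected to stay within the scatter. Compound 4 is estimated at 1200 nM, within 500 nM to 3000 nM.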

Compound 4, half-maximal inhibitory concentration: 2300 nM
Compound 4: middle estimate off by 1.9-fold (0.28 log units), on the low side; low and high end bracket the measured number.
By their numbers in this assay, from the lowest: compounds 2, 1, 3 and 4 (each within the scatter of the next, the first and the last beyond it).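

The exchange of 5-methylfuran-2-yl for 5-methylthiophen-2-yl gives a 1.5-fold higher number from compound 1 to compound 4 (0.19 log units; within the scatter) in this assay, the only direct reading of this change among the compounds shown. At this position, therefore, the two rings cannot be told apart on this read-out. No measured information is available to explain the result.

The compounds shown leave open whether a different group at this position, such as an amine or a carboxylic acid, would move the number beyond the scatter. They also leave open whether the same exchange would read alike with methyl in place of methoxy.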